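Triazole N-aryl variation on the shared core

This account rests on a few compounds, and the source may have more. Where it says the series, first, only, none or still open, it means among the compounds named here.

compound 1 `C/C(=C\CC/C(C)=C/CC[C@@H]1[C@@]2(C)CCC(=O)C(C)(C)[C@H]2CC[C@@]1(C)O)CC/C=C(\C)C(=O)OCc1cn(-c2ccccc2C(F)(F)F)nn1` — > 150000 nM in an ADME assay on L132 cells (Homo sapiens) for cytotoxicity, read by MTT assay, with a stated time of 48 h; a lower number here means a stronger inhibitor, a higher number a weaker inhibitor
compound 2 `C/C(=C\CC/C(C)=C/CC[C@@H]1[C@@]2(C)CCC(=O)C(C)(C)[C@H]2CC[C@@]1(C)O)CC/C=C(\C)C(=O)OCc1cn(-c2ccc(C(C)(C)C)cc2)nn1` — 65800 nM
compound 3 `C/C(=C\CC/C(C)=C/CC[C@@H]1[C@@]2(C)CCC(=O)C(C)(C)[C@H]2CC[C@@]1(C)O)CC/C=C(\C)C(=O)OCc1cn(-c2ccc(C)cc2)nn1` — > 150000 nM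

The three measured compounds share one core and differ only in the aryl group on the aromatic nitrogen of the triazole. For compound 1 the value is a limit of the assay, not a number. For compound 3 the value is likewise a limit. Compound 2 alone gives a number, so an at least 2.2-fold lower number from compound 1 to compound 2 (0.35 log units; beyond the scatter) and an at least 2.2-fold higher number from compound 2 to compound 3 (0.35 log units; beyond the scatter) are read against the limit, while a step that the two limits leave unreadable from compound 1 to compound 3 cannot be read at all; both limits sit at the limit of > 150000 nM in this assay, at which 2 of the 3 values shown sit.

For the measured compounds named here, compound 3 therefore stands at the limit, with compound 1 beside it and compound 2 the only value below it.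

Compound 4 `C/C(=C\CC/C(C)=C/CC[C@@H]1[C@@]2(C)CCC(=O)C(C)(C)[C@H]2CC[C@@]1(C)O)CC/C=C(\C)C(=O)OCc1cn(-c2ccccc2F)nn1` carries the change (2-fluorophenyl in place of 4-methylphenyl on an aromatic nitrogen). Of the measured steps, an at least 2.2-fold higher number from compound 2 to compound 3 (0.35 log units; beyond the scatter) shows that a smaller substituent on the phenyl returns the value to the limit, and compound 1, which also carries a substituent on the phenyl position named in its group, sits at the limit too. The expectation is therefore that compound 4 stays at or near the limit, with a number no higher from compound 3 to compound 4 (the limit leaves the size open) as the expected step from compound 3, no clear direction beyond the scatter. The estimate for compound 4 in this assay is 150000 nM, in the range 70000 nM to 300000 nM.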

Compound 4, half-maximal inhibitory concentration: > 150000 nM
Compound 4 ended at the assay's limit; the forecaster's own chance of this, stated with the estimate: 70%; the middle value sits exactly at the limit.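

With 2-fluorophenyl on the aromatic nitrogen, the series now shows an at least 2.2-fold higher number from compound 2 to compound 4 (0.35 log units; beyond the scatter), which leaves compound 2 as the only one of the four that gives a number in this assay: the limit of > 150000 nM in this assay, at which 3 of the 4 values shown sit.

Compound 4 gives > 150000 nM, which is a limit of the assay and not a number. The steps to compound 4 from compound 1 and from compound 3 cannot be read, as each joins two limits, so 2-fluorophenyl, 2-(trifluoromethyl)phenyl and 4-methylphenyl cannot be put in any order here.

The compounds shown leave open whether the number seen with 4-(tert-butyl)phenyl belongs to that group alone, or whether another group on the aromatic nitrogen, such as a phenyl bearing an amine or a carboxylic acid, or a longer alkyl chain in place of the phenyl, would also give a number. They also leave open how far the true values of compound 1, compound 3 and compound 4 lie from the limit and from one another.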